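A few compounds are considered here, and "the series" means these few. Any claim that something is new, unique, unknown or untested is made for them only; others in the source may bear on it.

Working notes on the series. In an assay for inhibition of kynurenine 3-monooxygenase (Homo sapiens), read by mass spectrometry, with a stated time of 1 h (a higher number here means a weaker inhibitor, a lower number a stronger inhibitor), compound 1 `O=C(O)CCn1c(=O)oc2cc(OCc3ccccc3)c(Cl)cc21` gives 25.1 nM, compound 2 `CC(C)Cc1cc2oc(=O)n(CCC(=O)O)c2cc1Cl` gives 12.6 nM, and compound 3 `C[C@@H](Oc1cc2oc(=O)n(CCC(=O)O)c2cc1Cl)c1ccc(Cl)cn1` gives 3.16 nM, the lowest of the three numbers, with its steps to compound 2 and to compound 1 both beyond the scatter. Among the measured compounds shown here, the only measured step, a 2.0-fold lower number from compound 1 to compound 2 (0.30 log units; within the scatter), sits on an aromatic carbon of the shared core and does not touch the chain carbon where compound 4 `C[C@@H](Oc1cc2oc(=O)n(CCC(=O)O)c2cc1Cl)c1cccnn1` differs from compound 3: pyridazin-3-yl in place of 5-chloropyridin-2-yl on a saturated chain carbon bound to an oxygen on an aromatic ring and a saturated chain carbon. For the measured compounds named here, no measured step bears directly on this exchange, so the expectation rests on compound 3 alone. A modest rise in this assay is expected, a 2.5-fold higher number from compound 3 to compound 4 (0.40 log units; beyond the scatter). Compound 4 is therefore estimated at 8 nM, within a range of 2.5 nM to 25 nM.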

Compound 4, half-maximal inhibitory concentration: 1.26 nM
The estimate for compound 4 lay 6.3-fold (0.80 log units) above the measured number; measured number outside the range, below it.
By their numbers in this assay, from the lowest: compound 4; then compound 3; then compounds 2 and 1 (each within the scatter of the next).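

In this assay the exchange on the saturated chain carbon gives a 2.5-fold lower number from compound 3 to compound 4 (0.40 log units; beyond the scatter), so this position accepts a ring with 2 hetero atoms and no chlorine with no loss in this assay. Across the whole group on the oxygen on an aromatic ring, the change gives a 20-fold lower number from compound 1 to compound 4 (1.30 log units; beyond the scatter), the largest step in the series so far. Nothing at hand bears on the reason for either step.

As far as these compounds go, whether the lower number follows the added ring nitrogen or the departing chlorine stays open. Pyridin-2-yl at this carbon would separate the two.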